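The source may hold more compounds than are shown below. What is called first, only, known or untested is meant among the compounds shown, and "the series" means these compounds.

Compound 1 `CC(C)(C)c1ccc(OC(=O)c2cn(-c3ccccc3)nc2-c2cccnc2)cc1` was examined in a functional assay on MCF7 cells (Homo sapiens) for cytotoxicity, read by MTT assay, with a stated time of 48 h; a lower number here means a stronger inhibitor, a higher number a weaker inhibitor. In this assay compound 1 gives only a limit, > 100000 nM, and not a single number. Compound 2 `O=C(Oc1ccc2ccccc2c1)c1cn(-c2ccccc2)nc1-c1cccnc1` belongs to the same set; in this assay compound 2 returned "nd(insoluble)" (no result reported), so no value exists for it. Compound 1 therefore stands at the limit of > 100000 nM in this assay, at which 1 of the 2 values shown sits, and nothing else among the measured entries offers a second number to compare with.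

Compound 3 `CC(C)(C)c1ccc(OC(=O)c2cn(-c3ccccc3)nc2-c2ccncc2)cc1` has not yet been measured in this assay. It differs from compound 1 by pyridin-4-yl in place of pyridin-3-yl on an aromatic carbon. For the measured compounds named here, no step between two measured compounds is available to show what such a change does, so the expectation rests on compound 1 alone. The expected step is a number no higher from compound 1 to compound 3 (the limit leaves the size open), none beyond the usual scatter. Compound 3 is accordingly estimated at 100000 nM, with a range from 30000 nM to 300000 nM, and most likely again only a limit.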

Compound 3, half-maximal inhibitory concentration: 32300 nM
For compound 3 the middle estimate is 3.1-fold (0.49 log units) above the measured one; measured number inside the range.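

For the compounds shown here, on this aromatic carbon, pyridin-4-yl in place of pyridin-3-yl yields the first single number in this assay, with an at least 3.0-fold lower number from compound 1 to compound 3 (0.49 log units; beyond the scatter). The two compounds have the same atoms joined differently, so moving the ring nitrogen within this one group is enough to shift the result beyond the usual scatter. The size of the step can be read only as a lower bound because compound 1 gives a limit and not a number: the limit of > 100000 nM in this assay, at which 1 of the 3 values shown sits.

Going by these compounds, whether a pyridin-2-yl or a plain phenyl group on this carbon would lower the number further remains open. So does whether the step would hold if an amine or a carboxylic acid replaced the tert-butyl group of compound 3.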